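Swapping Ethyl for Ethylsulfanyl on a Weak Inhibitor

The source may report more compounds than this note shows. Statements on the series, on what has been measured and on what is new or still open speak of the compounds shown alone.

Three compounds were tested in a functional assay; a lower number here means a stronger inhibitor, a higher number a weaker inhibitor. Compound 1 `CCOc1ccc2nc(S)sc2c1` gives 88400 nM. Compound 2 `CCc1nn(CCSS(=O)(=O)O)c(=N)s1` gives 51900 nM in this assay; its number is the lower of the two, but the gap to compound 1 lies within the usual scatter, so the two cannot be ranked. Compound 3 `CCOc1ccc2c(c1)sc(=N)n2CCSS(=O)(=O)O` was insoluble, and in this assay compound 3 is recorded as "nd(insoluble)" (no result reported), so no number was obtained. Compound 4 `CCSc1nn(CCSS(=O)(=O)O)c(=N)s1` has not yet been measured. It differs from compound 2 in one place: ethylsulfanyl in place of ethyl on an aromatic carbon. Within the data shown here, no measured pair shows a change of this kind, and nothing here points to a shift beyond the scatter, so the step of a 1.2-fold lower number from compound 2 to compound 4 (0.06 log units; within the scatter) is expected to be small. Compound 4 is therefore expected to give about 45000 nM in this assay, estimated between 15000 nM and 150000 nM.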

Compound 4, half-maximal inhibitory concentration: 8320 nM
The estimate for compound 4 lay 5.4-fold (0.73 log units) above the measured number; measured number below the stated range.
By their numbers in this assay, from the lowest: compound 4; then compounds 2 and 1 (each within the scatter of the next).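

In this assay, among these compounds, ethylsulfanyl in place of ethyl on this aromatic carbon gives a 6.2-fold lower number from compound 2 to compound 4 (0.80 log units; beyond the scatter) and so provides the first step in this set that lies beyond the scatter. This shows that the group on this carbon can change the number, and that a change as small as adding one sulfur atom to the group is enough. Nothing measured here explains why.

Going by these compounds, it remains open whether the sulfur atom alone accounts for the step. On these data alone, it is also open how a methylsulfanyl group, a longer propylsulfanyl chain or an amine on this carbon would compare.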